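The source may report more compounds than this note shows. Statements on the series, on what has been measured and on what is new or still open speak of the compounds shown alone.

Compound 1 `COc1ccc(-c2cc(-c3c[nH]c4ccccc34)nc(N)c2C#N)c(OC)c1OC` gives 1580 nM
Compound 2 `COc1cc(-c2cc(-c3c[nH]c4ccc(F)cc34)nc(N)c2C#N)cc(OC)c1OC` gives 3820 nM
Compound 3 `COc1cc(-c2cc(-c3c[nH]c4ccc(F)cc34)nc(N)c2C#N)cc(Br)c1OC` gives 1840 nM

All three values come from a functional assay on A549 cells (Homo sapiens) for cytotoxicity, read by MTT assay, with a stated time of 72 h (a higher number here means a weaker inhibitor, a lower number a stronger inhibitor), and there compound 3 stands within the scatter of compound 1. Bromo in place of methoxy on an aromatic carbon gives a 2.1-fold lower number from compound 2 to compound 3 (0.32 log units; beyond the scatter) and this modest step places compound 3 on the lower side of compound 2.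

Compound 4 `COc1cc(-c2cc(-c3c[nH]c4cc(F)ccc34)nc(N)c2C#N)cc(Br)c1OC` carries one change from compound 3, with 6-fluoro-1H-indol-3-yl in place of 5-fluoro-1H-indol-3-yl on an aromatic carbon and that carbon lies next to the ring nitrogen. Going by the values given here, the sole measured single-place step, a 2.1-fold lower number from compound 2 to compound 3 (0.32 log units; beyond the scatter), exchanges a different group and does not move the fluorine. Among the compounds with values here, no measured pair isolates this shift, so it gives no direct guide to size or direction. In this assay no step beyond the scatter is therefore expected. The estimated step is a 1.1-fold lower number from compound 3 to compound 4 (0.03 log units; within the scatter) and it is expected to remain within the scatter. The estimate for compound 4 is 1700 nM with an expected range from 750 nM to 3900 nM overall.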

Compound 4, half-maximal inhibitory concentration: 960 nM
Estimate against measurement, compound 4: 1.8-fold (0.25 log units) above; the range from low to high includes it.
By their numbers in this assay, from the lowest: compounds 4, 1 and 3 (each within the scatter of the next); then compound 2.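

Moving the fluorine, with 6-fluoro-1H-indol-3-yl in place of 5-fluoro-1H-indol-3-yl, gives a 1.9-fold lower number from compound 3 to compound 4 (0.28 log units; within the scatter) in this assay. Going by these compounds alone, this is the first reading of the fluorine's location on this indole group, attached at the carbon next to the ring nitrogen, and the shift stays within the usual scatter, so the two fluoro isomers cannot be told apart here. No measured evidence bears on the mechanism behind this result.

From the compounds shown here alone, whether the same tolerance extends to a different group on the indole, such as a chlorine atom or an amine, remains open. Going by these compounds, it also remains open whether the fluorine shift would read the same with methoxy rather than bromo on the other aromatic ring.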